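Urea-to-amide exchange on the shared core

This account rests on a few compounds, and the source may have more. Where it says the series, first, only, none or still open, it means among the compounds named here.

Three analogues on one core have been measured. Compound 1 `CN1CCC(C(=O)N2Cc3c(NC(=O)Nc4cccc(F)c4)n[nH]c3C2(C)C)CC1` gives 350 nM in a functional assay on A2780 cells (Homo sapiens) for antiproliferative activity, read by fluorescence, with a stated time of 72 h; on this read-out higher numbers stand for weaker inhibition and lower numbers for stronger inhibition. Compound 2 `CN1CCC(C(=O)Nc2n[nH]c3c2CN(C(=O)C(C)(C)C)C3(C)C)CC1` gives 350 nM in this assay, and compound 3 `CC(C)CC(=O)Nc1n[nH]c2c1CN(C(=O)C1CCN(C3CC3)CC1)C2(C)C` gives 320 nM. The three numbers sit within the usual scatter of one another, so compound 1 is level with compound 2 and with compound 3, and no ordering among them can be read from these values.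

The next compound, compound 4 `CN1CCC(C(=O)N2Cc3c(NC(=O)c4ccccc4)n[nH]c3C2(C)C)CC1`, is not yet measured. It differs from compound 1 in one place: phenyl in place of (3-fluorophenyl)amino on a carbonyl carbon. The change cut one bond further out reads (3-fluorophenyl)carbamoyl to benzoyl. Within the data shown here, no pair among the measured compounds carries this change, so its effect has no precedent here.

The expectation for compound 4 is a step toward a weaker number, though the estimate carries a wide range, and the expected step of a 2.0-fold higher number from compound 1 to compound 4 (0.30 log units; within the scatter) lies only modestly beyond the scatter. Compound 4 is thus estimated at 700 nM, within 250 nM to 2500 nM.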

Compound 4, half-maximal inhibitory concentration: 160 nM
For compound 4 the middle estimate is 4.4-fold (0.64 log units) above the measured one; measured number below the stated range.
By their numbers in this assay, from the lowest: compounds 4, 3, 1 and 2 (each within the scatter of the next, the first and the last beyond it).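

In this assay, among these compounds, phenyl in place of (3-fluorophenyl)amino on a carbonyl carbon gives a 2.2-fold lower number from compound 1 to compound 4 (0.34 log units; beyond the scatter), the first step that can be read at a single place. This position therefore accepts the change from (3-fluorophenyl)carbamoyl to benzoyl without loss of activity, and the step is modest but lies beyond the usual scatter. Nothing among the data shown accounts for this step.

As far as these compounds go, the change removes the amino nitrogen and the fluorine together, so their separate contributions remain open; 3-fluorobenzoyl and phenylamino on the same carbonyl carbon would separate them. Also open, from the compounds shown here alone, is whether the phenyl ring itself matters, which a cyclohexyl or pyridyl ring at this place would test.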